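The source may report more compounds than this note shows. Statements on the series, on what has been measured and on what is new or still open speak of the compounds shown alone.

The shared core of compound 1 `COc1cc(C)cc(-c2c(-c3ccnc(-c4ccc(C(C)=O)cc4)c3)cnn2CC#N)c1` carries an acetyl group on its outer phenyl ring, and in a functional assay on UACC-257 cells (Homo sapiens) for cytotoxicity, read by sulforhodamine B assay, with a stated time of 48 h, tested at 0.01 uM (a lower number here means a stronger effect, a higher number a weaker effect of the compound at the concentration tested), compound 1 gives 81%. The two companions measured alongside it sit close by: compound 2 `Cc1cc(O)cc(-c2nn(CC#N)cc2-c2ccnc(-c3ccc(Oc4ccccc4)cc3)c2)c1` gives 80% in this assay, and compound 3 `COc1cc(C)cc(-c2nn(CC#N)cc2-c2ccnc(-c3ccc(N(C)C)cc3)c2)c1` gives 91% there. Compound 1 therefore lies within the usual scatter of both compound 2 and compound 3, and the three numbers cannot be told apart with confidence; all of them point to a weak effect at the concentration tested.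

Compound 4 `COc1cc(C)cc(-c2c(-c3ccnc(-c4ccc(N(C)C)cc4)c3)cnn2CC#N)c1` is the next member and has not yet been measured. It differs from compound 1 in one place: dimethylamino in place of acetyl on an aromatic carbon. Going by the values given here, no measured pair shows this exact exchange, so its size can only be estimated. Compound 3, which also carries a dimethylamino group on a differently arranged core, gives 91%, a number no further from compound 1 than the scatter allows. Compound 4 is therefore expected to show a step from compound 1 of a number 5 percentage points higher from compound 1 to compound 4 (within the scatter), that is, none beyond the scatter. On that basis compound 4 is estimated at 86%, within a range from 72% to 98%.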

Compound 4, a percentage reported as activity, at one concentration (the size of the read-out at that concentration, not a potency): 38%
Compound 4: the middle estimate sits 48 percentage points above what was measured; measured number below the stated range.
By their numbers in this assay, from the lowest: compound 4; then compounds 2, 1 and 3 (each within the scatter of the next, the first and the last beyond it).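

Replacing 4-acetylphenyl with 4-(dimethylamino)phenyl on the shared core gives a number 43 percentage points lower from compound 1 to compound 4 (beyond the scatter) in this assay, the first difference in this series beyond the scatter, and shows that this place, para to a large group, responds strongly to the group it carries. Acetyl and dimethylamino have the same heavy-atom and hydrogen-bond-acceptor counts, so those counts do not separate the two compounds. Nothing available here explains why the exchange has so large an effect.

The compounds shown leave open whether this step is specific to dimethylamino or would also appear with a primary amine, a methoxy group or a diethylamino group in the same place. They also leave open whether the exchange would have the same effect on the differently arranged core of compound 3.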